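Swapping Chloro for Iodo at the Assay Limit

The source may report more compounds than this note shows. Statements on the series, on what has been measured and on what is new or still open speak of the compounds shown alone.

Measured compounds:
compound 1, `Nc1ccc(-c2nc3ccc(F)cc3s2)cc1Cl`, < 10 nM
compound 2, `Nc1ccc(-c2nc3cc(F)ccc3s2)cc1Br`, < 10 nM

In a functional assay on IGROV-1 cells (Homo sapiens) for inhibition (a lower number here means a stronger inhibitor of growth, a higher number a weaker inhibitor of growth), compound 1 gives < 10 nM, which is a limit of the assay and not a number. In this assay compound 2 likewise gives < 10 nM, again a limit. Going by the values given here, compound 1 therefore stands at the limit, and so does the one other value shown, because of the limit of < 10 nM in this assay, at which 2 of the 2 values shown sit. Among the compounds with values here, no step between two measured compounds is known, so the size of any effect in this assay can only be guessed.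

The unmeasured compound 3, `Nc1ccc(-c2nc3ccc(F)cc3s2)cc1I`, differs from compound 1 by iodo in place of chloro on an aromatic carbon. With both measured values sitting at the limit, no step beyond the scatter is expected from compound 1 to compound 3, so the estimated change is a step that the limit leaves unreadable from compound 1 to compound 3. Compound 3 is expected to give about 5 nM in this assay, in a range from 1 nM to 20 nM, and quite possibly only another limit.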

Compound 3, concentration for 50% growth inhibition: < 10 nM
Compound 3 ended at the assay's limit (the forecaster's own chance of this, stated with the estimate: 60%); the middle value is on the limit's open side.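

No step from compound 1 to compound 3 can be read in this assay, because both stand at a limit of the assay and not at a number: the limit of < 10 nM in this assay, at which 3 of the 3 values shown sit.

The compounds shown leave open whether iodo in place of chloro on an aromatic carbon changes growth inhibition at all, and by how much.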